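This account rests on a few compounds, and the source may have more. Where it says the series, first, only, none or still open, it means among the compounds named here.

In a functional assay on NCI-H460 cells (Homo sapiens) for antiproliferative activity, with a stated time of 72 h (a higher number here means a weaker inhibitor, a lower number a stronger inhibitor), compound 3 `Cc1ccccc1-c1cc([C@@H]2O[C@H](CO)[C@@H](O)[C@H]2O)n2ncnc(N)c12` gives > 100000 nM, which is a limit of the assay and not a number. In this assay, compound 1 `Nc1ncnn2c([C@@H]3O[C@H](CO)[C@@H](O)[C@H]3O)cc(C#CC3CC3)c12` gives 80 nM and compound 2 `Nc1ncnn2c([C@@H]3O[C@H](CO)[C@@H](O)[C@H]3O)cc(-c3ccc(F)cc3)c12` gives 55500 nM.

The change under review leads to compound 4 `Nc1ncnn2c([C@@H]3O[C@H](CO)[C@@H](O)[C@H]3O)cc(-c3ccsc3)c12`: thiophen-3-yl in place of 2-methylphenyl on an aromatic carbon of the shared core, (thiophen-3-yl in place of 2-methylphenyl on an aromatic carbon).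

Among the compounds with values here, three measured steps bear on this carbon. Placing a six-membered aromatic ring there instead of 2-cyclopropylethynyl gave two large steps, a 690-fold higher number from compound 1 to compound 2 (2.84 log units; beyond the scatter) and an at least 1200-fold higher number from compound 1 to compound 3 (3.09 log units; beyond the scatter). The exchange of one such ring for the other gave an at least 1.8-fold higher number from compound 2 to compound 3 (0.25 log units; that floor lies within the scatter), and that floor lies within the scatter. No measured step involves a five-membered aromatic ring, so the size of this change is not directly shown.

Compound 4 keeps an aromatic ring at this carbon, so it is expected to fall much nearer compound 2, at 55500 nM, than compound 1, at 80 nM. A move toward a lower number in this assay is expected, though a result at the limit remains possible. The expected step is an at least 16-fold lower number from compound 3 to compound 4 (1.22 log units; beyond the scatter). For compound 4 the estimate is 6000 nM, with an expected range of 500 nM to 60000 nM.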

Compound 4, half-maximal inhibitory concentration: 35600 nM
The estimate for compound 4 lay 5.9-fold (0.77 log units) below the measured number, and the stated range covers the measured number.
By their numbers in this assay, from the lowest: compound 1; then compounds 4 and 2 (each within the scatter of the next). At a limit, above all of these: compound 3.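

In this assay, the large loss on leaving 2-cyclopropylethynyl also holds for a five-membered aromatic ring at this carbon, with a 450-fold higher number from compound 1 to compound 4 (2.65 log units; beyond the scatter). Thiophen-3-yl and 4-fluorophenyl are not told apart, with a 1.6-fold lower number from compound 2 to compound 4 (0.19 log units; within the scatter), so exchanging the six-membered aromatic ring of compound 2 for this five-membered one does not register here. Compound 3 is held at a limit of the assay and not a number, so the exchange of its 2-methylphenyl gives only a floor, an at least 2.8-fold lower number from compound 3 to compound 4 (0.44 log units; beyond the scatter), yet this is the first floor among the aromatic rings at this carbon to clear the scatter: the limit of > 100000 nM in this assay, at which 1 of the 4 values shown sits.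

On these data alone, it remains open whether the low number of compound 1, at 80 nM, needs both the triple bond and the cyclopropyl end, which a plain ethynyl group or a saturated 2-cyclopropylethyl chain at this carbon would test. As far as these compounds go, it is also open whether an amine or a carboxylic acid on the thiophene ring would move the number at all.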